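A few compounds are considered here, and "the series" means these few. Any claim that something is new, unique, unknown or untested is made for them only; others in the source may bear on it.

Compound 1 `CCCc1c(OCCCCCC(=O)O)ccc(C(C)=O)c1O` carries a carboxy group at the end of a chain attached to the shared core. In a functional assay on ileum (Cavia porcellus) for inhibition of cysteinyl leukotriene receptor (Homo sapiens) (on this read-out higher numbers stand for higher potency (the scale is a negative logarithm) and lower numbers for lower potency), compound 1 gives 6, the lowest of the three numbers measured here. Compound 2 `CCCc1c(OCCCCCCc2nn[nH]n2)ccc(C(C)=O)c1O` gives 7.1 in this assay, and compound 3 `CCCc1c(OCCCCCc2nn[nH]n2)ccc(C(C)=O)c1O` gives 6.6; the step of a number 1.10 log units higher from compound 1 to compound 2 (beyond the scatter) and the step of a number 0.60 log units higher from compound 1 to compound 3 (beyond the scatter) both lie beyond the scatter.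

Compound 4 `CCCc1c(OCCCCCCC(=O)O)ccc(C(C)=O)c1O` keeps the acid but lengthens the chain: carboxymethyl in place of carboxy on a saturated chain carbon, five bonds along the chain from an oxygen on an aromatic ring. Among the measured compounds shown here, no measured pair shows exactly this change for an acid. The closest guide is the pair of tetrazole compounds, where one fewer chain carbon gave a number 0.50 log units lower from compound 2 to compound 3 (beyond the scatter), so one more chain carbon should count in the opposite direction. A modest rise in this assay is therefore expected, so that compound 4 is estimated at 6.4, between 5.9 and 6.9, an expected step of a number 0.40 log units higher from compound 1 to compound 4 (beyond the scatter).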

Compound 4, negative logarithm of the antagonist equilibrium constant: 5.7
The estimate for compound 4 lay 0.70 log units above the measured number; the measured number lies below the stated range.
By their numbers in this assay, from the lowest: compounds 4 and 1 (each within the scatter of the next); then compound 3; then compound 2.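

In this assay, lengthening the carboxy chain gives a step that cannot be told from scatter, a number 0.30 log units lower from compound 1 to compound 4 (within the scatter), whereas chain length did register in the tetrazole pair, a number 0.50 log units lower from compound 2 to compound 3 (beyond the scatter). Both tetrazole compounds also stand clear of the longer acid, with a number 0.90 log units lower from compound 3 to compound 4 (beyond the scatter) and a number 1.40 log units lower from compound 2 to compound 4 (beyond the scatter). The gain from placing a tetrazole in the position of the carboxy group is therefore not a fixed amount, but differs with the chain that carries it: the same change on two cores in this assay, a number 0.60 log units higher (beyond the scatter) from compound 1 to compound 3 and a number 1.40 log units higher (beyond the scatter) from compound 4 to compound 2, 0.80 log units apart, beyond the scatter of two such steps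

The compounds shown leave open how a still longer chain would behave, whether it ends in a carboxylic acid or in a tetrazole. They also leave open whether another end group on the same chain, such as a primary amide or a sulfonamide, would follow either pattern.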